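Moving the chlorine on the ring carbon from 4- to 3-position

This account rests on a few compounds, and the source may have more. Where it says the series, first, only, none or still open, it means among the compounds named here.

Compound 3 `NS(=O)(=O)c1ccc(NC(=O)CSc2nnc(N3C(=O)CSC3c3ccc(Cl)cc3)s2)cc1` carries a 4-chlorophenyl group on a saturated ring carbon of its core. In an ADME assay on MT4 cells (Homo sapiens) for cytotoxicity, read by MTT assay, with a stated time of 5 days (a higher number here means that more compound is tolerated, a lower number that less compound is tolerated), compound 3 gives only a limit, >= 222000 nM, not a number. Compound 1 `NS(=O)(=O)c1ccc(NC(=O)CSc2nnc(N3C(=O)CSC3c3ccccc3Cl)s2)cc1` differs from compound 3 only by having 2-chlorophenyl at the same place. In this assay compound 1 also gives only a limit, >= 18800 nM. The step that the two limits leave unreadable from compound 1 to compound 3 therefore cannot be read, and the two limits the limit of >= 18800 nM in this assay, at which 1 of the 3 values shown sits, and the limit of >= 222000 nM in this assay, at which 1 of the 3 values shown sits, mark where the two values sit. Compound 2 `CS(=O)(=O)c1ccc(NC(=O)CSc2nnc(N3C(=O)CSC3c3cccc(Cl)c3)s2)cc1` bears 3-chlorophenyl and a methylsulfonyl group instead of the sulfonamide; in this assay compound 2 gives 113000 nM.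

Compound 4 `NS(=O)(=O)c1ccc(NC(=O)CSc2nnc(N3C(=O)CSC3c3cccc(Cl)c3)s2)cc1` is to be measured. The change from compound 3 is 3-chlorophenyl in place of 4-chlorophenyl on a saturated ring carbon. Among the measured compounds shown here, no measured step covers this exact change, and the one measured step between the chlorophenyl isomers stays unreadable. The value of compound 2, whose chlorophenyl matches compound 4, together with the limit of compound 3, suggests that the shift to 3-chlorophenyl changes little.

Compound 4 is therefore expected to fall near compound 2 and within the scatter of compound 3, with an estimated value of 150000 nM, ranging from 50000 nM to 400000 nM. The expected step of an at least 1.4-fold lower number from compound 3 to compound 4 (0.17 log units; that floor lies within the scatter) is estimated as small.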

Compound 4, half-maximal cytotoxic concentration: 118000 nM
The estimate for compound 4 lay 1.3-fold (0.10 log units) above the measured number; the range from low to high includes it.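

In this assay, among the compounds shown here, 3-chlorophenyl in place of 4-chlorophenyl on the saturated ring carbon gives an at least 1.8-fold lower number from compound 3 to compound 4 (0.27 log units; that floor lies within the scatter), the first step at this position with a number at one end; being only a floor, it does not show whether moving the chlorine matters here. Amino in place of methyl on the sulfonyl sulfur, with 3-chlorophenyl held the same, gives a 1.0-fold higher number from compound 2 to compound 4 (0.02 log units; within the scatter), so the sulfonamide and the methylsulfonyl compound cannot be told apart in this pair. The step to compound 4 that starts from compound 1 cannot be read, since compound 1 gives only a limit: the limit of >= 18800 nM in this assay, at which 1 of the 4 values shown sits.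

On these data alone, whether the sulfonamide and methylsulfonyl groups also match when the ring carries 2-chlorophenyl or 4-chlorophenyl stays open. So does what a methoxy group or an amine in place of the chlorine, or a carboxylic acid in place of the sulfonyl group, would give in this assay on this same core.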